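Replacing methylsulfanyl with hydroxy on a dienamide

This account rests on a few compounds, and the source may have more. Where it says the series, first, only, none or still open, it means among the compounds named here.

Measured so far:
- compound 1, `CN(C)c1ccc(/C=C/C=C/C(=O)N2CCCCC2)cc1`: 13.4%
- compound 2, `O=C(/C=C/c1ccc(O)c(O)c1)N1CCCCC1`: 55.2%
- compound 3, `CSc1ccc(/C=C/C=C/C(=O)N2CCCCC2)cc1`: 11.8%

In an assay for inhibition of Polyunsaturated fatty acid 5-lipoxygenase (Homo sapiens), read by spectrophotometry, tested at 20 uM (a higher number here means more inhibition at the concentration tested (going by the name of the read-out), a lower number less inhibition), compound 3 sits at the low end of the three numbers. The nearest is compound 1, whose value lies within the usual scatter of it, so no order between the two can be read; the furthest is compound 2, whose value lies well beyond the scatter. Going by the values given here, the one step between compounds that differ in a single place, a number 1.6 percentage points lower from compound 1 to compound 3 (within the scatter), is within the scatter.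

Compound 4, `O=C(/C=C/C=C/c1ccc(O)cc1)N1CCCCC1`, differs from compound 3 in one place: hydroxy in place of methylsulfanyl on an aromatic carbon. Among the compounds with values here, no measured step concerns a hydroxy swapped for another group on its own. Compound 2 carries hydroxy groups and gives a higher value in this assay, but it also differs from compound 3 in its chain, so its two values show only that much. Compound 4 is therefore expected to give a modestly higher reading than compound 3, a step of a number 15.2 percentage points higher from compound 3 to compound 4 (beyond the scatter), with wide uncertainty. The estimate for compound 4 is 27%, in a range of 8% to 48%.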

Compound 4, a percentage reported as inhibition, at one concentration (the size of the read-out at that concentration, not a potency): 44.4%
Compound 4: middle estimate off by 17.4 percentage points, on the low side; the range from low to high includes it.
By their numbers in this assay, from the lowest: compounds 3 and 1 (each within the scatter of the next); then compound 4; then compound 2.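

In this assay, hydroxy on this aromatic carbon gives a number 32.6 percentage points higher from compound 3 to compound 4 (beyond the scatter) in place of methylsulfanyl and a number 31 percentage points higher from compound 1 to compound 4 (beyond the scatter) in place of dimethylamino. The earlier swap between those two groups gave only a number 1.6 percentage points lower from compound 1 to compound 3 (within the scatter) and so showed no effect, whereas these steps show that the reading on the shared core can depend strongly on the group at this place. Hydroxy carries one hydrogen-bond donor and methylsulfanyl none, but no measurement here ties the rise to that difference or to any other cause.

From the compounds shown here alone, it remains open whether a methoxy, an amino group or a carboxylic acid at this place would give a similar reading. Compound 2 differs from compound 4 in more than one place, so the separate contributions of its shorter chain and second hydroxy also remain unresolved.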